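Dropping a Fluorine from the Benzyl Arm

The source may report more compounds than this note shows. Statements on the series, on what has been measured and on what is new or still open speak of the compounds shown alone.

Compound 1, `COc1ccc(-c2cnc3nc(N)nc(N4CCN(c5ccc(C)cc5)CC4)c3n2)cc1OC`: 300 nM
Compound 2, `COc1ccc(-c2cnc3nc(N)nc(N4CCN(Cc5ccccc5F)CC4)c3n2)cc1OC`: 700 nM
Compound 3, `Cc1ccc(-c2cnc3nc(N)nc(OC(C)C)c3n2)cc1C`: 10000 nM

These three compounds were tested in a functional assay on cells (T-cell, Homo sapiens) for inhibition; a higher number here means a weaker inhibitor, a lower number a stronger inhibitor. Compound 2 holds the second highest of the three numbers. Within the data shown here, its nearest neighbour is compound 1, and the step of a 2.3-fold higher number from compound 1 to compound 2 (0.37 log units; beyond the scatter) is the one measured change in a single place. Compound 3 lies furthest away; it differs from compound 2 in several places at once, so its higher number cannot be tied to any one group.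

Compound 4, `COc1ccc(-c2cnc3nc(N)nc(N4CCN(Cc5ccccc5)CC4)c3n2)cc1OC`, is not yet measured. It differs from compound 2 in one place: hydrogen in place of fluoro on an aromatic carbon. Among the measured compounds shown here, no measured step in this set removes a fluoro on its own. The step from compound 1 to compound 2 exchanges the whole group on the amine nitrogen in the ring, so it only shows that this arm can be varied with a modest change in the number. For the measured compounds named here, with no closer precedent, the expectation for this assay is a step no larger than the scatter, in no particular direction. The expected step is no change at the digits printed from compound 2 to compound 4 (within the scatter). Compound 4 is therefore estimated at 700 nM, with a range from 300 nM to 1600 nM.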

Compound 4, half-maximal inhibitory concentration: 900 nM
Estimate against measurement, compound 4: 1.3-fold (0.11 log units) below, and the stated range covers the measured number.
By their numbers in this assay, from the lowest: compound 1; then compounds 2 and 4 (each within the scatter of the next); then compound 3.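

In this assay, among these compounds, taking the fluoro off the benzyl ring gives a 1.3-fold higher number from compound 2 to compound 4 (0.11 log units; within the scatter), so the 2-fluorobenzyl and benzyl arms cannot be told apart, and this single-atom exchange is the first direct test of the fluoro at this place. Set against the 4-methylphenyl arm, the plain benzyl arm gives a 3.0-fold higher number from compound 1 to compound 4 (0.48 log units; beyond the scatter), a modest step beyond the scatter, so among these compounds the readable difference comes from exchanging the whole arm on the ring nitrogen and not from the fluoro. No evidence is available here to explain these numbers.

The compounds shown leave open whether this tolerance holds only for the small fluoro or extends to a chloro, a trifluoromethyl or a methoxy group on the same aromatic ring. They also leave open how the number would respond to a longer chain linking the phenyl ring to the ring nitrogen, or to an amine or a carboxylic acid carried on that arm.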